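Three chalcone-type thioethers and a fourth, as yet unmeasured

The source may hold more compounds than are shown below. What is called first, only, known or untested is meant among the compounds shown, and "the series" means these compounds.

Compound 1 `COc1ccc(/C=C(/Sc2ccc(C)cc2)C(=O)c2ccc(Br)cc2)cc1`: 50000 nM
Compound 2 `CCOc1ccc(/C=C(/SCc2ccc(F)cc2)C(=O)c2ccc(Br)cc2)cc1OC`: 50000 nM
Compound 3 `COc1ccc(/C=C(/SCc2ccc(F)cc2)C(=O)c2ccc(Br)cc2)cc1`: 50000 nM

In a functional assay on DU-145 cells (Homo sapiens) for inhibition, read by trypan blue exclusion, with a stated time of 96 h (on this read-out lower numbers stand for stronger inhibition of growth and higher numbers for weaker inhibition of growth), compound 3 gives 50000 nM, and compound 1 gives 50000 nM. The change from compound 3 to compound 1 is 4-methylphenyl in place of 4-fluorobenzyl on a sulfur, and the step it made is no change at the digits printed from compound 3 to compound 1 (within the scatter). Compound 2 gives 50000 nM; how the core of compound 2 differs from that of compound 3 is not broken down here.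

Compound 4 `CCOc1ccc(/C=C(/Sc2ccc(C)cc2)C(=O)c2ccc(Br)cc2)cc1OC` is not yet measured. It differs from compound 2 by 4-methylphenyl in place of 4-fluorobenzyl on a sulfur, the same change as from compound 3 to compound 1, at the same place. Because no change at the digits printed from compound 3 to compound 1 (within the scatter), the step from compound 2 to compound 4 is expected to be no change at the digits printed from compound 2 to compound 4 (within the scatter). Compound 4 is therefore estimated at 50000 nM, between 25000 nM and 100000 nM.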

Compound 4, concentration for 50% growth inhibition: 50000 nM
Estimate against measurement, compound 4: no gap at the digits printed, within the range that was stated.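

In this assay, 4-methylphenyl in place of 4-fluorobenzyl on a sulfur gives no change at the digits printed from compound 2 to compound 4 (within the scatter). Set beside the same change on the other core, the step carries over: the same change on two cores in this assay, no change at the digits printed (within the scatter) from compound 3 to compound 1 and no change at the digits printed (within the scatter) from compound 2 to compound 4, 1.0-fold (0.00 log units) apart, within the scatter of two such steps This agreement shows only that the change leaves the reading where it stands on these two cores; all four compounds print the same value, so it does not show how the change would behave on a core with a lower reading.

The compounds shown leave open whether any group on that sulfur moves the reading at all. An amine, a carboxylic acid or a longer chain in place of 4-methylphenyl remains an open case.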